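Swapping Selenium for Sulfur in a Cytotoxicity Series

The source may hold more compounds than are shown below. What is called first, only, known or untested is meant among the compounds shown, and "the series" means these compounds.

Compound 1, `COc1ccc(CNc2nc([Se]C)nc3ccccc23)cc1`: in a functional assay on MCF7 cells (Homo sapiens) for cytotoxicity, read by MTT assay, with a stated time of 72 h (on this read-out lower numbers stand for higher toxicity in this test and higher numbers for lower toxicity in this test), compound 1 gives only the assay limit > 100000 nM.
Compound 2, `[SeH]c1nc([SeH])c2cccnc2n1`: compound 2 gives 82700 nM.
Compound 3, `C[Se]c1nc(NCc2ccccc2)c2ccccc2n1`: compound 3 gives only the limit > 100000 nM.

Compound 1 therefore stands at the limit of > 100000 nM in this assay, at which 2 of the 3 values shown sit, not at a measured number. Among the measured compounds shown here, the one step between measured compounds, a step that the two limits leave unreadable from compound 1 to compound 3, cannot be read for the same reason. Compound 4, `COc1ccc(CNc2nc(SC)nc3ccccc23)cc1`, differs from compound 1 by a group of 2 heavy atoms (1 carbon, 1 sulfur; no ring) in place of a group of 2 heavy atoms (1 carbon, 1 selenium; no ring), on an aromatic carbon. For the measured compounds named here, no measured step covers this swap, so the step is not expected to carry compound 4 clearly away from the limit; the estimate is a step that the limit leaves unreadable from compound 1 to compound 4. Compound 4 is estimated at 120000 nM, within 40000 nM to 300000 nM, most likely reported again as a limit.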

Compound 4, concentration lethal to 50% of the cells: > 100000 nM
Compound 4 was reported as a limit; the forecaster's own chance of this, stated with the estimate: 70%; the middle value lies beyond the limit too.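

Compound 1 and compound 4 both give only an assay limit, not a number, so no step between them can be read: the limit of > 100000 nM in this assay, at which 3 of the 4 values shown sit.

As far as these compounds go, whether exchanging selenium for sulfur changes toxicity in this assay stays open.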